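Oral exposure of the trioxolane series: chain amine in place of piperidine

A few compounds are considered here, and "the series" means these few. Any claim that something is new, unique, unknown or untested is made for them only; others in the source may bear on it.

Compound 1 `c1cc([C@H]2CC[C@]3(CC2)OOC2(O3)C3CC4CC(C3)CC2C4)ccc1OCCC1CCNCC1` is the reference point. Among the measured compounds shown here, in an ADME assay on the whole organism (strain FVB) for pharmacokinetics, with Mus musculus as the target, read by LC-MS, at a dose of 30 mg/kg by the oral route (a lower number here means less compound in the circulation, a higher number more compound in the circulation at the dose given), compound 1 gives 1190 nM, the highest of the two numbers so far, though its nearest neighbour sits within the scatter. That neighbour is compound 2 `c1cc([C@H]2CC[C@]3(CC2)OOC2(O3)C3CC4CC(C3)CC2C4)ccc1OC1CCNCC1`, which in this assay gives 810 nM; the step of a 1.5-fold lower number from compound 1 to compound 2 (0.17 log units; within the scatter) shows that shortening the link between the aromatic oxygen and the piperidine did not move the read-out beyond noise.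

Compound 3 `NCCCCOc1ccc([C@H]2CC[C@]3(CC2)OOC2(O3)C3CC4CC(C3)CC2C4)cc1` is not yet measured. Its change from compound 1 is 2-aminoethyl in place of piperidin-4-yl on a saturated chain carbon, two bonds along the chain from an oxygen on an aromatic ring. For the measured compounds named here, the only measured step that bears on it is a 1.5-fold lower number from compound 1 to compound 2 (0.17 log units; within the scatter), which touches the same side chain on the aromatic oxygen and was within the scatter. Going by the values given here, no measured pair shows what replacing the piperidine ring by an open chain amine does, so the expectation for compound 3 is a step of a 1.3-fold lower number from compound 1 to compound 3 (0.12 log units; within the scatter) that stays within the scatter, with the direction uncertain. For compound 3 the expected maximal plasma concentration in this assay is 900 nM, with a range from 300 nM to 2700 nM.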

Compound 3, maximal plasma concentration: 370 nM
For compound 3 the middle estimate is 2.4-fold (0.39 log units) above the measured one, and the stated range covers the measured number.
By their numbers in this assay, from the lowest: compound 3; then compounds 2 and 1 (each within the scatter of the next).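

In this assay, among the compounds shown here, the change from the piperidine ring to an open chain amine, read as 4-aminobutoxy in place of 2-(piperidin-4-yl)ethoxy, is the first change to move the read-out beyond the scatter, with a 3.2-fold lower number from compound 1 to compound 3 (0.51 log units; beyond the scatter) as the result. The comparison with the shorter piperidin-4-yl side chain points the same way and also lies beyond the scatter, at a 2.2-fold lower number from compound 2 to compound 3 (0.34 log units; beyond the scatter) for 4-aminobutyl in place of piperidin-4-yl on an oxygen on an aromatic ring, so the open chain amine stands lowest of the three while the two piperidines remain within the scatter of each other. Nothing available here bears on why the open chain amine gives less compound in the circulation.

The compounds shown hold a single open chain amine, so it remains open whether the lower number goes with the loss of the ring or with this particular chain length. A shorter 3-aminopropyl chain, a longer 5-aminopentyl chain or a dimethylamino group at the chain end would help to separate those readings.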